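Series notes: from bromo to nitro in compound 3

The source may report more compounds than this note shows. Statements on the series, on what has been measured and on what is new or still open speak of the compounds shown alone.

Measured in a functional assay on MCF7 cells (Homo sapiens) for cytotoxicity, read by MTT assay, with a stated time of 96 h; on this read-out lower numbers stand for stronger inhibition and higher numbers for weaker inhibition:
- compound 1 `COc1cc(C(=O)c2cn(-c3ccccc3)cc2-c2cccc(Cl)c2)cc(OC)c1OC`: 540 nM
- compound 2 `COc1cc(C(=O)c2cn(-c3ccccc3)cc2-c2ccc(Br)cc2)cc(OC)c1OC`: 340 nM

Compound 2, at 340 nM, stands within the scatter of compound 1, at 540 nM, so the two cannot be ranked. Compound 3 `COc1cc(C(=O)c2cn(-c3ccccc3)cc2-c2ccc([N+](=O)[O-])cc2)cc(OC)c1OC` has nitro in place of bromo on an aromatic carbon, para to a large group: nitro in place of bromo on an aromatic carbon.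

Within the data shown here, no measured step covers this exchange, so its size in this assay is not known directly. Among the measured compounds shown here, the only step that bears on it is a 1.6-fold lower number from compound 1 to compound 2 (0.20 log units; within the scatter), which puts 4-bromophenyl in place of 3-chlorophenyl. That single step is thin evidence, and a nitro group has not yet been measured in this series. On this basis, no step beyond the scatter is expected in this assay, and no direction can be assigned. The expected change is a 1.2-fold higher number from compound 2 to compound 3 (0.07 log units; within the scatter), a small estimated step given with low confidence. For compound 3 the estimated value is 400 nM, with an expected range of 130 nM to 1200 nM.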

Compound 3, half-maximal inhibitory concentration: 590 nM
Estimate against measurement, compound 3: 1.5-fold (0.17 log units) below, and the stated range covers the measured number.
By their numbers in this assay, from the lowest: compounds 2, 1 and 3 (each within the scatter of the next).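

Among these compounds, with nitro in place of bromo on an aromatic carbon, para to a large group, this assay shows a 1.7-fold higher number from compound 2 to compound 3 (0.24 log units; within the scatter) and so gives the first direct reading of this exchange at this place. With 4-nitrophenyl in place of 3-chlorophenyl, this assay shows a 1.1-fold higher number from compound 1 to compound 3 (0.04 log units; within the scatter) and leaves compound 1, compound 2 and compound 3 unranked. This place therefore carries either bromo, with one heavy atom and no hydrogen-bond acceptors, or nitro, with three heavy atoms and two hydrogen-bond acceptors, with no step beyond the scatter, although three compounds give only a narrow view of it. No measurement at hand explains why these numbers stay so close.

From the compounds shown here alone, whether the same holds for an amine, a carboxylic acid or a longer chain such as butyl at this place remains open, as any of these could still give a step beyond the scatter. Also open, going by these compounds, is whether nitro in place of bromo gives a similar step on a differently substituted core or in a read-out other than this assay on these cells.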